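The compounds below may be only part of what the source reports. "The series", "measured", "known", "first", "only" and "open" are said of these compounds alone.

The compounds share one core, and what varies among them is the group on an aromatic nitrogen of a five-membered aromatic ring with 3 nitrogen. For the measured compounds named here, compound 1 `COc1ccccc1-n1cc(COc2c(/C=C\C(=O)O)ccc(OC)c2CC=C(C)C)nn1` is the only member with a number: in a functional assay on A549 cells (Homo sapiens) for cytotoxicity, read by MTT assay, with a stated time of 24 h (a higher number here means a weaker inhibitor, a lower number a stronger inhibitor), compound 1 gives 43000 nM, a weak effect. Compound 2 `COc1ccc(/C=C\C(=O)O)c(OCc2cn(-c3cccc(C#N)c3)nn2)c1CC=C(C)C` gives "not determined" (no result reported) in this assay, and compound 3 `COc1ccc(/C=C\C(=O)O)c(OCc2cn(-c3ccccc3C(=O)N3CCC(O)C3)nn2)c1CC=C(C)C` gives "not determined" (no result reported) in this assay, so compound 2 stands without a number to lean on. Compound 4 `COc1ccc(/C=C\C(=O)O)c(OCc2cn(-c3ccc(C#N)cc3)nn2)c1CC=C(C)C` differs from compound 2 in one place: 4-cyanophenyl in place of 3-cyanophenyl on an aromatic nitrogen. Going by the values given here, with no measured step from the 3-cyanophenyl to the 4-cyanophenyl and only compound 1 as a guide, no step beyond the scatter in this assay is expected in either direction. Compound 4 is therefore estimated near 45000 nM, within 15000 nM to 150000 nM.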

Compound 4, half-maximal inhibitory concentration: 42200 nM
The estimate for compound 4 lay 1.1-fold (0.03 log units) above the measured number, within the range that was stated.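

Swapping 2-methoxyphenyl for 4-cyanophenyl on an aromatic nitrogen gives a 1.0-fold lower number from compound 1 to compound 4 (0.01 log units; within the scatter) in this assay. The position now carries two numbers rather than one, and these two different aryl groups do not separate in this assay. No supporting measurement accounts for this result.

Steps involving compound 2 and compound 3 cannot be read, so the 3-cyanophenyl and 4-cyanophenyl groups cannot be compared. As far as these compounds go, whether a phenyl ring bearing an amine or a carboxylic acid, or a longer alkyl chain on this nitrogen, would shift the number remains open.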